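Cytotoxicity in BJ Cells: From Triflate to Bromophenyl

The source may hold more compounds than are shown below. What is called first, only, known or untested is meant among the compounds shown, and "the series" means these compounds.

Compound 1 `C=C[C@@](C)(/C=C/c1ccc(OS(=O)(=O)C(F)(F)F)cc1)CCC=C(C)C` in an ADME assay on BJ cells (Homo sapiens) for cytotoxicity, with a stated time of 72 h; a lower number here means that less compound is needed, a higher number that more compound is needed for the effect: > 36600 nM
Compound 2 `C=C[C@@](C)(/C=C/c1ccc(OS(=O)(=O)c2ccc(C)cc2)cc1)CCC=C(C)C` in this assay: > 36600 nM
Compound 3 `COc1ccc(/C=C/[C@@](C)(/C=C/c2ccc(O)c(C=O)c2)CCC=C(C)C)cc1` in this assay: 9800 nM

In this assay compound 1 gives > 36600 nM, which is a limit of the assay and not a number. Compound 2 likewise stops at a limit, > 36600 nM. Of the three values shown, two sit at the limit of > 36600 nM in this assay, at which 2 of the 3 values shown sit, and only compound 3, with 9800 nM, gives a number. Within the data shown here, the one step between neighbours, a step that the two limits leave unreadable from compound 1 to compound 2, therefore tells nothing about its size.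

Compound 4 `C=C[C@@](C)(/C=C/c1ccc(-c2cccc(Br)c2)cc1)CCC=C(C)C` differs from compound 1 by 3-bromophenyl in place of ((trifluoromethyl)sulfonyl)oxy on an aromatic carbon. Among the measured compounds shown here, no measured step concerns this change; the only measured step, from a trifluoromethyl to a 4-methylphenyl on a sulfonyl sulfur, is unreadable, and compound 3 is altered elsewhere. The expectation for compound 4 thus rests only on compound 1 standing at a limit and compound 3 showing that a number within reach of the assay can occur in this series. Compound 4 is estimated at 25000 nM, within 8000 nM to 80000 nM, so the expected step is an at least 1.4-fold lower number from compound 1 to compound 4 (0.16 log units; that floor lies within the scatter).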

Compound 4, half-maximal effective concentration: > 36600 nM
Compound 4: only a limit was reported; the forecaster's own chance of this, stated with the estimate: 50%; middle value at least 1.4-fold (0.16 log units) from the limit.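

Compound 4, like compound 1, ends at a limit and not a number in this assay, so no step from compound 1 to compound 4 can be read: the limit of > 36600 nM in this assay, at which 3 of the 4 values shown sit.

The compounds shown leave open whether 3-bromophenyl in place of ((trifluoromethyl)sulfonyl)oxy changes the result in this assay at all.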